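From ethynyloxy to hexyl on the shared core

This account rests on a few compounds, and the source may have more. Where it says the series, first, only, none or still open, it means among the compounds named here.

Compound 3 `C#COc1cn([C@H]2C[C@H](O)[C@@H](CO)O2)c(=O)[nH]c1=O` gives > 200000 nM in an ADME assay on L1210/0 cells (Mus musculus) for cytotoxicity, with a stated time of 48 h (a lower number here means a stronger inhibitor, a higher number a weaker inhibitor), as a limit of the assay and not a number. Compound 1 `O=c1[nH]c(=O)n([C@H]2C[C@H](O)[C@@H](CO)O2)cc1CO` gives 9180 nM in this assay and compound 2 `C=C(Cl)c1cn([C@H]2C[C@H](O)[C@@H](CO)O2)c(=O)[nH]c1=O` gives 1660 nM in the same test. Among the measured compounds shown here, compound 4 `CCCCCCc1cn([C@H]2C[C@H](O)[C@@H](CO)O2)c(=O)[nH]c1=O` carries hexyl in place of ethynyloxy on an aromatic carbon and no measured step introduces hexyl. Among changes on this carbon a 5.5-fold lower number from compound 1 to compound 2 (0.74 log units; beyond the scatter) was modest. With an at least 21-fold higher number from compound 1 to compound 3 (1.33 log units; beyond the scatter) and an at least 120-fold higher number from compound 2 to compound 3 (2.08 log units; beyond the scatter) both large and both leading into compound 3 the departure of ethynyloxy is expected to bring a modest move toward a lower number in this assay and the limit may recur. The expected change is an at least 2.5-fold lower number from compound 3 to compound 4 (0.39 log units; beyond the scatter) by this estimate. Compound 4 is expected at 80000 nM within a range of 20000 nM to 200000 nM as estimated.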

Compound 4, half-maximal inhibitory concentration: > 200000 nM
Compound 4 gave a limit, no number; the forecaster's own chance of this, stated with the estimate: 35%; at least 2.5-fold (0.39 log units) between middle value and limit.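

In this assay, among the compounds shown here, compound 4 gives a limit and not a number, so ethynyloxy is no longer the only group on this carbon to reach it: the limit of > 200000 nM in this assay, at which 2 of the 4 values shown sit. Hexyl, which holds only carbon and no triple bond, also ends far from the two measured compounds, with an at least 120-fold higher number from compound 2 to compound 4 (2.08 log units; beyond the scatter) and an at least 21-fold higher number from compound 1 to compound 4 (1.33 log units; beyond the scatter) in the same test. The step between compound 3 and compound 4 cannot be read, since both are limits.

From the compounds shown here alone, whether a shorter chain such as propyl, or an amine on this carbon, would give a number stays open.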